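The compounds below may be only part of what the source reports. "The series", "measured", "known", "first", "only" and "open" are said of these compounds alone.

Measured compounds in a functional assay on A549 cells (Homo sapiens) for inhibition, read by sulforhodamine B assay, with a stated time of 72 h; a lower number here means a stronger inhibitor of growth, a higher number a weaker inhibitor of growth:
Compound 1, `CNC(=O)CCc1ccncc1-c1ccc2ccccc2c1`, gives 10400 nM.
Compound 2, `O=C(O)CCc1ccncc1-c1ccc2ccccc2c1`, gives only a limit of the assay, > 10000 nM.
Compound 3, `CNC(=O)/C=C/c1ccncc1-c1ccc2[nH]ccc2c1`, gives only a limit of the assay, > 10000 nM.

Compound 4, `O=C(O)/C=C/c1ccncc1-c1ccc2[nH]ccc2c1`, is not yet measured in this assay. From compound 1 to compound 2 the change is hydroxy in place of methylamino on a carbonyl carbon; the step is a step that the limit leaves unreadable from compound 1 to compound 2, its size unreadable because the limit of > 10000 nM in this assay, at which 2 of the 3 values shown sit, caps it. From compound 3 to compound 4 the change is hydroxy in place of methylamino on a carbonyl carbon, the same kind of change, though here the carbonyl carbon sits on a double-bonded chain carbon rather than on a saturated chain carbon. The difference between the two cores is not broken down here. Compound 3 itself sits at a limit of the assay. For compound 4 a step that the limit leaves unreadable from compound 3 to compound 4 is expected, read off the unreadable acid step in the first pair. Compound 4 is thus estimated at 20000 nM, with a range from 8000 nM to 60000 nM, and will most likely be reported again only as a limit.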

Compound 4, concentration for 50% growth inhibition: > 10000 nM
Compound 4 ended at the assay's limit; the forecaster's own chance of this, stated with the estimate: 85%; the middle value is on the limit's open side.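

No step can be read from compound 3 to compound 4 in this assay since both compounds give only a limit: the limit of > 10000 nM in this assay, at which 3 of the 4 values shown sit. From the compounds shown here alone, whether hydroxy in place of methylamino on a carbonyl carbon changes growth inhibition remains open for both chains.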